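The source may hold more compounds than are shown below. What is called first, only, known or untested is meant among the compounds shown, and "the series" means these compounds.

In a functional assay on MCF7 cells (Homo sapiens) for cytotoxicity, read by MTT assay, with a stated time of 72 h (on this read-out lower numbers stand for stronger inhibition and higher numbers for weaker inhibition), compound 1 (`COc1ccc(/C=C2\CCC/C(=C\c3cccc(Br)c3)C2=O)cc1OC`) gives 5300 nM and compound 2 (`COc1ccc(/C=C2\CCC/C(=C\c3ccc(Br)cc3)C2=O)cc1OC`) gives 6900 nM while compound 3 (`COc1cccc(/C=C2\CCC/C(=C\c3ccc(OC)c(OC)c3)C2=O)c1`) gives 4600 nM with all three within the scatter of each other. Compound 3 therefore stands level with both of the others. The change to compound 4 (`COc1ccc(/C=C2\CCC/C(=C\c3ccc(OC)c(OC)c3)C2=O)cc1`) is 4-methoxyphenyl in place of 3-methoxyphenyl on a double-bonded chain carbon bound to a double-bonded ring carbon. Among the measured compounds shown here, the closest precedent is the same change of place with bromo, the step of a 1.3-fold higher number from compound 1 to compound 2 (0.11 log units; within the scatter) which stays within the scatter. The exchanges of group, a 1.2-fold lower number from compound 1 to compound 3 (0.06 log units; within the scatter) and a 1.5-fold lower number from compound 2 to compound 3 (0.18 log units; within the scatter) also stay within it. With only these three steps to go on, no step beyond the scatter is expected in this assay and no direction can be assigned. The estimated step is a 1.1-fold higher number from compound 3 to compound 4 (0.04 log units; within the scatter) as a central figure only. Compound 4 is expected at 5000 nM with 2500 nM to 10000 nM as the estimated range.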

Compound 4, half-maximal inhibitory concentration: 7800 nM
The estimate for compound 4 lay 1.6-fold (0.19 log units) below the measured number, and the stated range covers the measured number.
By their numbers in this assay, from the lowest: compounds 3, 1, 2 and 4 (each within the scatter of the next).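

With methoxy as with bromo, 4-methoxyphenyl in place of 3-methoxyphenyl on a double-bonded chain carbon bound to a double-bonded ring carbon stays within the scatter in this assay, with a 1.7-fold higher number from compound 3 to compound 4 (0.23 log units; within the scatter). The exchange of 3-bromophenyl for 4-methoxyphenyl at this place, which alters both the group and its position, also stays within it, with a 1.5-fold higher number from compound 1 to compound 4 (0.17 log units; within the scatter), and a 1.1-fold higher number from compound 2 to compound 4 (0.05 log units; within the scatter) gives a second reading of methoxy in place of bromo on an aromatic carbon. That exchange now has a reading on each of two cores, and the two agree: the same change on two cores in this assay, a 1.2-fold lower number (0.06 log units; within the scatter) from compound 1 to compound 3 and a 1.1-fold higher number (0.05 log units; within the scatter) from compound 2 to compound 4, 1.3-fold (0.11 log units) apart, within the scatter of two such steps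

Going by these compounds, whether an amine, a carboxylic acid or a trifluoromethyl group at this place would give a step beyond the scatter remains open. Also open, on these data alone, is whether these flat steps hold in cells other than those of this assay.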